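A few compounds are considered here, and "the series" means these few. Any claim that something is new, unique, unknown or untested is made for them only; others in the source may bear on it.

Measured set in a functional assay on AN3-CA cells (Homo sapiens) for antiproliferative activity, read by MTT assay, with a stated time of 72 h; on this read-out higher numbers stand for weaker inhibition and lower numbers for stronger inhibition:

- compound 1 `O=C(Nc1ccc(Cl)c(-c2nnc3c(Cl)cccn23)c1)c1ccc(C(F)(F)F)cc1F`: 41200 nM
- compound 2 `Cc1cc(Cl)ccc1C(=O)Nc1ccc(Cl)c(-c2nnc3c(Cl)cccn23)c1`: a limit of this assay, > 100000 nM
- compound 3 `O=C(Nc1ccc(Cl)c(-c2nnc3c(Cl)cccn23)c1)c1ccc(C(F)(F)F)cc1Cl`: also a limit, > 100000 nM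

Compound 2 thus stands at a limit of this assay, with no number attached. Compound 4 `O=C(Nc1ccc(Cl)c(-c2nnc3c(Cl)cccn23)c1)c1cccnc1Cl` differs from it by 2-chloropyridin-3-yl in place of 4-chloro-2-methylphenyl on a carbonyl carbon. Going by the values given here, no measured step touches this exchange; the only step in hand, an at least 2.4-fold higher number from compound 1 to compound 3 (0.38 log units; beyond the scatter), concerns another ring and carries no direct bearing. What weighs here is the limit of > 100000 nM in this assay, at which 2 of the 3 values shown sit, so the step from compound 2 to compound 4 is expected to stay small, an at least 1.2-fold lower number from compound 2 to compound 4 (0.09 log units; that floor lies within the scatter), with a real chance of another limit. Compound 4 is therefore estimated at 80000 nM, within 20000 nM to 200000 nM.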

Compound 4, half-maximal inhibitory concentration: > 100000 nM
Compound 4: a limit, no number; the forecaster's own chance of this, stated with the estimate: 55%; middle value at least 1.2-fold (0.09 log units) from the limit.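

No step can be read between compound 2 and compound 4: both values are limits. The compounds shown leave open whether 2-chloropyridin-3-yl in place of 4-chloro-2-methylphenyl on a carbonyl carbon changes the antiproliferative read-out at all.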